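The compounds below may be only part of what the source reports. "The series", "measured", "known", "first", "only" and "open" are said of these compounds alone.

Compound 1 `Cc1cn([C@@H]2CC(F)(F)[C@H](CO)O2)c(=O)nc1O` is the starting point of this small set. In a functional assay on Vero cells (Chlorocebus sabaeus) for cytotoxicity (a lower number here means a stronger inhibitor, a higher number a weaker inhibitor), compound 1 gives > 100000 nM, which is a limit of the assay and not a number. Compound 2 `O=c1nc(O)ccn1[C@@H]1CC(F)(F)[C@H](CO)O1` is obtained from compound 1 by the change (hydrogen in place of methyl on an aromatic carbon). In this assay compound 2 gives > 100000 nM, again a limit rather than a number. The step that the two limits leave unreadable from compound 1 to compound 2 therefore cannot be sized; both of its ends sit at the limit described by the limit of > 100000 nM in this assay, at which 3 of the 3 values shown sit.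

Compound 3 `Cc1cn([C@@H]2C=C(F)[C@H](CO)O2)c(=O)nc1O` carries a different core from compound 1; the difference between the two cores is not broken down here. In this assay compound 3 gives > 100000 nM, which is once more a limit and not a number.

Compound 4 `O=c1nc(O)ccn1[C@@H]1C=C(F)[C@H](CO)O1` is not yet measured. It differs from compound 3 by the change (hydrogen in place of methyl on an aromatic carbon), the same kind of change as that from compound 1 to compound 2; the surroundings differ only in that the site is meta to a group of 8 heavy atoms in compound 3 and meta to a group of 9 heavy atoms in compound 1.

Since all three measured values sit at the limit described by the limit of > 100000 nM in this assay, at which 3 of the 3 values shown sit, the step from compound 3 to compound 4 is expected to be unreadable as well, with an estimated size of a step that the limit leaves unreadable from compound 3 to compound 4. For compound 4 in this assay the expected result is 150000 nM, with an estimated range from 50000 nM to 500000 nM, most likely reported only as a limit.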

Compound 4, half-maximal inhibitory concentration: > 100000 nM
Compound 4 ended at the assay's limit; the forecaster's own chance of this, stated with the estimate: 85%; the middle value is on the limit's open side.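

In this assay compound 4 gives > 100000 nM, which is a limit of the assay and not a number. Going by these compounds alone, no size can be read for the step between compound 3 and compound 4, so this result adds no new step: the limit of > 100000 nM in this assay, at which 4 of the 4 values shown sit. The compounds shown leave open what number any of them would give in this assay, and whether hydrogen in place of methyl on an aromatic carbon alters that number at all.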